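This account rests on a few compounds, and the source may have more. Where it says the series, first, only, none or still open, it means among the compounds named here.

Compound 1, `COc1cc2c(Oc3ccc(NC(=O)NN4C(=O)CSC4c4ccc(F)cc4)cc3)ccnc2cc1OC1CCN(C(=O)NCc2ccccc2)CC1`: 6600 nM
Compound 2, `COc1cc2c(Oc3ccc(NC(=O)NN4C(=O)CSC4c4ccc(F)c(F)c4)cc3)ccnc2cc1OC1CCN(C(=O)NC(C)C)CC1`: 1060 nM

In a functional assay on HT-29 cells (Homo sapiens) for inhibition, read by MTT assay (on this read-out lower numbers stand for stronger inhibition and higher numbers for weaker inhibition), compound 1 gives 6600 nM, whereas compound 2 gives 1060 nM, the lower of the two numbers, a gap that lies beyond the usual scatter. Compound 3, `COc1cc2c(Oc3ccc(NC(=O)NN4C(=O)CSC4c4ccc(F)cc4F)cc3)ccnc2cc1OC1CCN(C(=O)NC(C)C)CC1`, differs from compound 2 by 2,4-difluorophenyl in place of 3,4-difluorophenyl on a saturated ring carbon. Among the measured compounds shown here, no measured pair isolates such a change, so only a modest step is expected, in either direction. Compound 3 is estimated at 1500 nM, with a range of 500 nM to 5000 nM. This corresponds to an expected step of a 1.4-fold higher number from compound 2 to compound 3 (0.15 log units; within the scatter).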

Compound 3, half-maximal inhibitory concentration: 950 nM
Estimate against measurement, compound 3: 1.6-fold (0.20 log units) above; the range from low to high includes it.
By their numbers in this assay, from the lowest: compounds 3 and 2 (each within the scatter of the next); then compound 1.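

In this assay, 2,4-difluorophenyl in place of 3,4-difluorophenyl on the saturated ring carbon gives a 1.1-fold lower number from compound 2 to compound 3 (0.05 log units; within the scatter), so this rearrangement of the same atoms leaves the read-out within the scatter. Among the compounds shown here, the earlier compounds offered no pair differing in this one place, making this the only direct reading at this position. Nothing at hand bears on why the two groups read alike. Left open is how this carbon responds to an unsubstituted phenyl, a chlorophenyl or a pyridyl ring. Compound 1 differs from compound 2 in more than one place, and its gap cannot be assigned to either change.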